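This account rests on a few compounds, and the source may have more. Where it says the series, first, only, none or still open, it means among the compounds named here.

Measured so far in a functional assay on HeLa cells (Homo sapiens) for cytotoxicity, read by MTT assay, with a stated time of 48 h; on this read-out higher numbers stand for weaker inhibition and lower numbers for stronger inhibition:
Compound 1 `Cc1nc2c3ccccc3ccc2c2nc3c(ccc4ccccc43)c(-c3cccnc3)c12` gives 3860 nM.
Compound 2 `Cc1nc2c3ccccc3ccc2c2nc3c(ccc4ccccc43)c(-c3cccc4ccccc34)c12` gives 14900 nM.
Compound 3 `Cc1nc2c3ccccc3ccc2c2nc3c(ccc4ccccc43)c(-c3cc([N+](=O)[O-])ccc3N)c12` gives 5770 nM.

Compound 3 stands second highest of the three numbers in this assay. Its nearest neighbour is compound 1: a 1.5-fold higher number from compound 1 to compound 3 (0.17 log units; within the scatter). Its furthest is compound 2: a 2.6-fold lower number from compound 2 to compound 3 (0.41 log units; beyond the scatter). Among the measured compounds shown here, the only step that lies beyond the scatter among the first two is a 3.9-fold higher number from compound 1 to compound 2 (0.59 log units; beyond the scatter); all three steps exchange the whole aryl group on the shared core.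

The next compound, compound 4 `Cc1nc2c3ccccc3ccc2c2nc3c(ccc4ccccc43)c(-c3ccccc3N)c12`, differs from compound 3 in one place: hydrogen in place of nitro on an aromatic carbon. For the measured compounds named here, no measured step bears on this change directly; each of the three steps replaces the entire aryl substituent rather than removing a single group from it, and none removes a nitro group. The measured steps therefore give no direction for the change, and the two aryl groups that retain the amino group are the closest guide, with compound 3 itself as the anchor. Going by the values given here, with no step pointing either way, a step of no size beyond the scatter is expected in this assay.

Compound 4 is therefore expected to give about 5500 nM, with a range from 2500 nM to 12000 nM. The step this estimate implies, a 1.0-fold lower number from compound 3 to compound 4 (0.02 log units; within the scatter), is expected to stay within the scatter.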

Compound 4, half-maximal inhibitory concentration: 16200 nM
For compound 4 the middle estimate is 2.9-fold (0.47 log units) below the measured one; measured number outside the range, above it.
By their numbers in this assay, from the lowest: compounds 1 and 3 (each within the scatter of the next); then compounds 2 and 4 (each within the scatter of the next).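

In this assay, among the compounds shown here, the change from 2-amino-5-nitrophenyl to 2-aminophenyl is the first made within a single aryl group rather than by exchanging the whole group, and it moves the number beyond the scatter (a 2.8-fold higher number from compound 3 to compound 4 (0.45 log units; beyond the scatter)); the nitro group, on the carbon para to the amino group, therefore matters at this position in a way the earlier steps could not isolate. Without the nitro group, the amino-bearing aryl group no longer stands within the scatter of pyridin-3-yl (a 4.2-fold higher number from compound 1 to compound 4 (0.62 log units; beyond the scatter)) and instead falls within the scatter of naphthalen-1-yl (a 1.1-fold higher number from compound 2 to compound 4 (0.04 log units; within the scatter)), so the amino group alone does not keep the number close to that of compound 1. Nothing available accounts for the size of the nitro step.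

On these data alone, it remains open whether this gain is specific to nitro or would also appear with a nitrile, a trifluoromethyl group or a carboxylic acid on the same carbon. Also open, as far as these compounds go, is whether a nitro group on a phenyl ring lacking the amino group would give the same step.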